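A few compounds are considered here, and "the series" means these few. Any claim that something is new, unique, unknown or untested is made for them only; others in the source may bear on it.

In a functional assay on K562 cells (Homo sapiens), read by MTT assay, with a stated time of 72 h (a lower number here means a stronger inhibitor, a higher number a weaker inhibitor), compound 3 `CSc1ncnc2c1c(-c1cccs1)cn2[C@@H]1O[C@H](CO)[C@@H](O)[C@H]1O` gives 11600 nM. Going by the values given here, that is the higher of the two exact numbers so far, since compound 2 `C#Cc1cn([C@@H]2O[C@H](CO)[C@@H](O)[C@H]2O)c2ncnc(OC)c12` gives 300 nM. Compound 1 `COc1ncnc2c1c(-c1ccccc1)cn2[C@@H]1O[C@H](CO)[C@@H](O)[C@H]1O` reads > 20000 nM, which is a limit of the assay and not a number.

Compound 4 `CSc1ncnc2c1c(-c1ccccc1)cn2[C@@H]1O[C@H](CO)[C@@H](O)[C@H]1O` differs from compound 3 by a single swap, phenyl in place of thiophen-2-yl on an aromatic carbon.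

Among the compounds with values here, the one measured step at this place is an at least 66-fold lower number from compound 1 to compound 2 (1.82 log units; beyond the scatter), with ethynyl in place of phenyl. This large step shows that the group here can matter a great deal, and it leaves phenyl on the weak side. Yet compound 3 at 11600 nM is already weak with its thiophen-2-yl, and the swap only trades one aromatic ring for another. The expected step is small, toward a slightly higher number and probably within the scatter: a 1.4-fold higher number from compound 3 to compound 4 (0.14 log units; within the scatter). Compound 4 is estimated at 16000 nM, with an expected range from 6000 nM to 40000 nM.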

Compound 4, half-maximal inhibitory concentration: > 20000 nM
Compound 4: only a limit was reported; the forecaster's own chance of this, stated with the estimate: 40%; at least 1.2-fold (0.09 log units) between middle value and limit.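

In this assay, phenyl in place of thiophen-2-yl gives an at least 1.7-fold higher number from compound 3 to compound 4 (0.23 log units; that floor lies within the scatter), so this swap of one aromatic ring for another cannot be shown to move the number beyond ordinary scatter, although the true step could be larger. Compound 4 carries a limit of the assay and not a number, and it shows that a phenyl compound with methylsulfanyl on the shared core also reaches that limit, as compound 1 with methoxy does. The step between compound 1 and compound 4 cannot be read, since both sit at the same limit: the limit of > 20000 nM in this assay, at which 2 of the 4 values shown sit.

As far as these compounds go, it remains open whether ethynyl on this aromatic carbon would keep its low number with methylsulfanyl in place of methoxy. From the compounds shown here alone, it is also open how a non-aromatic group at this position, such as an amine or a longer carbon chain, would compare.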